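This account rests on a few compounds, and the source may have more. Where it says the series, first, only, none or still open, it means among the compounds named here.

Compound 1 `COc1cc(/C=C/C2=CC(=O)CC(c3ccc(O)c(OC)c3)N2CCCO)ccc1O` — > 100000 nM
Compound 2 `COCCCN1C(/C=C/c2ccc(O)cc2)=CC(=O)CC1c1ccc(O)cc1` — > 100000 nM
Compound 3 `COc1cc(/C=C/C(=O)/C=C(/C=C/c2ccc(O)c(OC)c2)NCCO)ccc1O` — > 100000 nM

All three measured compounds were examined in a functional assay on HepG2 cells (Homo sapiens) for cytotoxicity, read by MTT assay, with a stated time of 48 h; on this read-out lower numbers stand for stronger inhibition and higher numbers for weaker inhibition. For compound 3 the value > 100000 nM is a limit of the assay and not a number. For compound 1 the value > 100000 nM is likewise a limit. For compound 2 the value > 100000 nM is also a limit. Compound 3 thus stands exactly where the other two stand, and nothing among the shown numbers sets it apart: the limit of > 100000 nM in this assay, at which 3 of the 3 values shown sit.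

Compound 4 `COc1cc(/C=C/C(=O)/C=C(/C=C/c2ccc(O)c(OC)c2)NCCCO)ccc1O` differs from compound 3 in one place: hydroxymethyl in place of hydroxy on a saturated chain carbon, two bonds along the chain from an amine nitrogen. No step between two measured compounds is available to show what such a change does in this assay, and all three shown values sit at the same limit.

Given that compound 3 gives only a limit, > 100000 nM, the expectation is that compound 4 will show no step beyond the scatter, the expected step from compound 3 to compound 4 being a step that the limit leaves unreadable from compound 3 to compound 4. Compound 4 is therefore expected to fall around 150000 nM, within a range from 50000 nM to 500000 nM, most likely again reported only as a limit.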

Compound 4, half-maximal inhibitory concentration: > 100000 nM
Compound 4: only a limit was reported; the forecaster's own chance of this, stated with the estimate: 85%; the middle value lies beyond the limit too.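

No step can be read between compound 3 and compound 4, since neither gives a number in this assay: the limit of > 100000 nM in this assay, at which 4 of the 4 values shown sit.

The compounds shown leave open whether hydroxymethyl in place of hydroxy on a saturated chain carbon, two bonds along the chain from an amine nitrogen, makes any difference in this assay, and none of them gives a number against which that could be judged.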